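The source may report more compounds than this note shows. Statements on the series, on what has been measured and on what is new or still open speak of the compounds shown alone.

Three compounds have been measured in an assay on microsomes from liver for inhibition of 3-hydroxy-3-methylglutaryl-coenzyme A reductase (Sus scrofa), read by colorimetric assay; a higher number here means a weaker inhibitor, a lower number a stronger inhibitor:

Compound 1 `CC(C)=CCC/C(C)=C/CCC1=C[C@H](c2ccccc2)OC1=O`: 16500 nM
Compound 2 `CCc1ccc([C@H]2C=C(CC/C=C(\C)CCC=C(C)C)C(=O)O2)cc1`: 14200 nM
Compound 3 `COc1ccc([C@H]2C=C(CC/C=C(\C)CCC=C(C)C)C(=O)O2)cc1`: 6210 nM

All three share the same core and differ only in the group on the aromatic ring that sits on the saturated ring carbon. Compound 3, which carries the methoxy group, gives the lowest number of the three and is therefore the strongest inhibitor here: the change a 2.7-fold lower number from compound 1 to compound 3 (0.42 log units; beyond the scatter) and the change a 2.3-fold lower number from compound 2 to compound 3 (0.36 log units; beyond the scatter) both lie beyond the scatter. The step of a 1.2-fold lower number from compound 1 to compound 2 (0.07 log units; within the scatter), by contrast, lies within the scatter, so compounds 1 and 2 cannot be told apart.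

Compound 4 `CC(C)=CCC/C(C)=C/CCC1=C[C@H](c2cc(F)ccc2F)OC1=O` has not yet been measured. Its structural change from compound 3 is 2,5-difluorophenyl in place of 4-methoxyphenyl on a saturated ring carbon. For the measured compounds named here, no measured step shows what two fluorine atoms do. What the steps do show is that the methoxy group is tied to the modest gain seen in a 2.7-fold lower number from compound 1 to compound 3 (0.42 log units; beyond the scatter) and a 2.3-fold lower number from compound 2 to compound 3 (0.36 log units; beyond the scatter), and compound 4 loses that group. The number for compound 4 is therefore expected to move back toward that of compound 1, that is a 1.9-fold higher number from compound 3 to compound 4 (0.29 log units; within the scatter), with wide uncertainty. Compound 4 is estimated at 12000 nM, in a range from 5000 nM to 30000 nM.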

Compound 4, half-maximal inhibitory concentration: 25100 nM
Beside the measured number, compound 4's estimate is 2.1-fold (0.32 log units) below it; measured number inside the range.
By their numbers in this assay, from the lowest: compound 3; then compounds 2, 1 and 4 (each within the scatter of the next).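

In this assay, swapping the aromatic ring on this saturated ring carbon, next to the ring oxygen, for 2,5-difluorophenyl gives a compound that cannot be told apart from the phenyl or 4-ethylphenyl compounds: both (a 1.5-fold higher number from compound 1 to compound 4 (0.18 log units; within the scatter)) and (a 1.8-fold higher number from compound 2 to compound 4 (0.25 log units; within the scatter)) lie within the scatter. Only the 4-methoxyphenyl compound stands clearly apart (a 4.0-fold higher number from compound 3 to compound 4 (0.61 log units; beyond the scatter)), and with its steps to all three others now beyond the scatter, compound 3 is the strongest inhibitor of the four, while compounds 1, 2 and 4 form one group at this level of precision. No supporting evidence is available to explain why the 4-methoxyphenyl ring differs from the rest.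

Going by these compounds, compound 4 brings in both fluorine atoms in a single change, so the effect of each one alone remains unknown, and any effect of one could be masked by the other. On these data alone, it also remains open whether the gain belongs to the methoxy group specifically, since an ethoxy group, a hydroxy group or an amine on the same ring could show whether other groups give a similar result.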